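Aryl swap on the ring amine: compound 1 to compound 3

This account rests on a few compounds, and the source may have more. Where it says the series, first, only, none or still open, it means among the compounds named here.

Measured so far in a functional assay on HeLa cells (Homo sapiens) for antiproliferative activity, read by CCK-8 assay, with a stated time of 72 h, tested at 2 uM; a lower number here means a weaker effect, a higher number a stronger effect of the compound at the concentration tested:
- compound 1 `Nc1ccccc1NC(=O)c1ccc(CSC(=S)N2CCN(c3ccccc3)CC2)cc1`: 62.2%
- compound 2 `CC1CCN(C(=S)SCc2ccc(C(=O)Nc3ccccc3N)cc2)CC1`: 46.8%

Compound 1 gives the higher of the two numbers in this assay; compound 2 sits a step below it, and that gap lies beyond the usual scatter. Going by the values given here, no pair among the measured compounds differs in only one place, so no single-change step is available to calibrate the next move.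

Compound 3 `Nc1ccccc1NC(=O)c1ccc(CSC(=S)N2CCN(c3ncccn3)CC2)cc1` is the next compound. Relative to compound 1 the change is pyrimidin-2-yl in place of phenyl on an amine nitrogen in a ring. The remainder of the shared core of compound 1 is kept.

Among the compounds with values here, no measured step of this type exists, so the expected size of the step in this assay is judged from the spread between compound 1 and compound 2 alone. A change of this kind is expected to shift the read-out only modestly, most likely downward, with the outcome possibly falling within the scatter of compound 1. The estimated step from compound 1 to compound 3 is a number 7.2 percentage points lower from compound 1 to compound 3 (within the scatter). For compound 3 the estimate in this assay is 55%, with a range from 35% to 72%.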

Compound 3, a percentage reported as inhibition, at one concentration (the size of the read-out at that concentration, not a potency): 52.2%
Compound 3: the middle estimate sits 2.8 percentage points above what was measured; measured number inside the range.
By their numbers in this assay, from the lowest: compounds 2, 3 and 1 (each within the scatter of the next, the first and the last beyond it).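

In this assay the series now has its first step that changes one place only, and it reads a number 10 percentage points lower from compound 1 to compound 3 (within the scatter) for pyrimidin-2-yl in place of phenyl on an amine nitrogen in a ring. Both groups hold 6 heavy atoms, so the swap exchanges an aromatic ring of carbon only for one with 2 hetero atoms and 2 hydrogen-bond acceptors, and in this single pair that exchange does not carry the read-out beyond the usual scatter. Nothing on hand bears on why the step has this size.

From the compounds shown here alone, whether other groups on the same amine nitrogen, such as pyridin-2-yl, benzyl or acetyl, stay within the scatter of compound 1 remains open, as one pair gives no trend for this position. Also open, going by these compounds, is whether compound 1 and compound 3 would stay this close at other concentrations, since a read-out at one concentration is not a potency.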